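Working notes: carbonyl substituent step from compound 3 to compound 4

A few compounds are considered here, and "the series" means these few. Any claim that something is new, unique, unknown or untested is made for them only; others in the source may bear on it.

Measured compounds:
compound 1, `Cc1cccc(C#Cc2nc3c(s2)C(=O)NCC3)c1`; compound 2, `O=C1c2sc(C#Cc3ccccc3)nc2CN1C1CC1`; compound 3, `O=C(C1CC1)N1CCc2nc(C#Cc3ccccc3)sc2C1`.

In an assay on HEK293 cells for negative allosteric modulation of metabotropic glutamate receptor 5 (Homo sapiens), read by FLIPR, with a stated time of 1 h (a lower number here means a stronger inhibitor, a higher number a weaker inhibitor), compound 1 gives > 10000 nM, which is a limit and not a number, sitting at the limit of > 10000 nM in this assay, at which 1 of the 3 values shown sits. In this assay compound 2 gives 23 nM. Compound 3 gives 290 nM in this assay, the higher of the two numbers; compound 2 lies well below it, and that gap is beyond the scatter.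

Compound 4, `O=C(N1CCC(F)CC1)N1CCc2nc(C#Cc3ccccc3)sc2C1`, differs from compound 3 by 4-fluoropiperidin-1-yl in place of cyclopropyl on a carbonyl carbon. Within the data shown here, no measured pair covers such a change, so expectations rest on compound 3 alone. The step from compound 3 to compound 4 in this assay is expected to be small, no more than a modest loss, a 1.4-fold higher number from compound 3 to compound 4 (0.14 log units; within the scatter). Compound 4 is estimated at 400 nM, within 100 nM to 1600 nM.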

Compound 4, half-maximal inhibitory concentration: > 10000 nM
Compound 4 gave a limit, no number (the forecaster's own chance of this, stated with the estimate: 10%); at least 25-fold (1.39 log units) between middle value and limit.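

At the carbonyl carbon, this position proves far less tolerant than compound 3 alone could show: 4-fluoropiperidin-1-yl in place of cyclopropyl gives an at least 34-fold higher number from compound 3 to compound 4 (1.53 log units; beyond the scatter) in this assay. Compound 4 stands at a limit, not a number: the limit of > 10000 nM in this assay, at which 2 of the 4 values shown sit. The change alters ring size, ring nitrogen and fluorine together, so the loss cannot be assigned to any one of them.

Open, as far as these compounds go, is whether piperidin-1-yl without the fluorine behaves like compound 4. Also open, from the compounds shown here alone, is whether a dimethylamino or tert-butyl group on the carbonyl carbon retains the level of compound 3.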